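The source may hold more compounds than are shown below. What is called first, only, known or untested is meant among the compounds shown, and "the series" means these compounds.

Three measured compounds share one core, an aminomethyl-bearing biaryl amide carrying a fluoropyridine, and differ only in the ester-bearing ring at the far end. Compound 1 `CCCOC(=O)c1cccc(C(=O)Nc2cccc(-c3cc(C(=O)Nc4ccncc4F)ccc3CN)c2)c1`, with a propyl ester, gives 1.8 nM in an assay on cells for inhibition of Rho-associated protein kinase 2 (Homo sapiens), read by radiometric assay and 33P incorporation, in the presence of a further agent that is not named here; a lower number here means a stronger inhibitor, a higher number a weaker inhibitor. Compound 2 `CCCCOC(=O)c1cccc(NC(=O)c2cccc(-c3cc(C(=O)Nc4ccncc4F)ccc3CN)c2)c1`, the butyl ester, gives 27 nM in this assay. Compound 3 `CCCOC(=O)c1ccc(NC(=O)c2cccc(-c3cc(C(=O)Nc4ccncc4F)ccc3CN)c2)cc1` is a propyl ester on a ring whose substitution pattern differs from that of compound 1. In this assay compound 3 gives a result that is a limit of the measurement rather than a number, < 1 nM; one of the three results sits at this limit (the limit of < 1 nM in this assay, at which 1 of the 3 values shown sits).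

Of the two actual numbers, compound 2 has the higher one, and its gap to compound 1 is beyond the usual scatter of repeated measurements, so compound 2 is the weaker inhibitor of those two.

Compound 4 `CCC(C)OC(=O)c1cccc(NC(=O)c2cccc(-c3cc(C(=O)Nc4ccncc4F)ccc3CN)c2)c1` has not yet been measured. It keeps every atom of compound 2 but joins them differently: sec-butyl in place of butyl on an oxygen next to a carbonyl group. Among the compounds with values here, no measured pair shows what such branching of the ester chain does here. The step from compound 2 to compound 4 in this assay is therefore expected to be small, a 1.1-fold lower number from compound 2 to compound 4 (0.03 log units; within the scatter), with no direction that can be trusted beyond the scatter. Compound 4 is estimated at 25 nM, within a range from 8 nM to 80 nM.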

Compound 4, half-maximal inhibitory concentration: 2.6 nM
Compound 4: the middle estimate sits 9.6-fold (0.98 log units) above what was measured, outside the stated range (below it).
By their numbers in this assay, from the lowest: compounds 1 and 4 (each within the scatter of the next); then compound 2. At a limit, below all of these: compound 3.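

Branching the ester chain turns out to matter a great deal at this position: sec-butyl in place of butyl on an oxygen next to a carbonyl group gives a 10-fold lower number from compound 2 to compound 4 (1.02 log units; beyond the scatter) in this assay and leaves the atoms themselves unchanged. The atom count of the chain therefore does not settle the result here, since the butyl and sec-butyl esters hold the same atoms and differ only in how they are joined. This is also the first pair among the compounds shown that differs in one place only, so it gives the first direct reading of the ester chain on its own, which the earlier compounds, differing in more than one place, could not give.

On these data alone, one pair cannot show whether branching has the same effect on other esters, and how an isopropyl ester, a tert-butyl ester or a carboxylic acid would read at this position remains open. Compound 3 also gives a limit and not a number, which leaves its exact standing open: the limit of < 1 nM in this assay, at which 1 of the 4 values shown sits.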